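Shortening the Alkenyl Chain on the Sulfonyl Group

The source may report more compounds than this note shows. Statements on the series, on what has been measured and on what is new or still open speak of the compounds shown alone.

Compound 1 `C=CCCCCCCCS(=O)(=O)/C=C/c1ccc(O)c(O)c1` carries a hept-6-en-1-yl chain on its sulfonyl sulfur. Among the measured compounds shown here, in a functional assay, read by fluorescence and spectrophotometry, with a stated time of 1 h (a lower number here means that less compound is needed, a higher number that more compound is needed for the effect), compound 1 gives 6900 nM, the lowest number of the three measured so far, though all three lie within the scatter of one another: compound 2 `O=S(=O)(/C=C/c1ccc(O)c(O)c1)CCC1CCCCC1` gives 9800 nM and compound 3 `CCCCCCCCCS(=O)(=O)/C=C/c1ccc(O)c(O)c1` gives 7700 nM. Compound 4 `C=CCCCCCS(=O)(=O)/C=C/c1ccc(O)c(O)c1` differs from compound 1 by vinyl in place of but-3-en-1-yl on a saturated chain carbon, five bonds along the chain from a sulfonyl sulfur. The steps measured so far all alter this same chain and all stay within the scatter: a 1.4-fold higher number from compound 1 to compound 2 (0.15 log units; within the scatter), a 1.1-fold higher number from compound 1 to compound 3 (0.05 log units; within the scatter) and a 1.3-fold lower number from compound 2 to compound 3 (0.10 log units; within the scatter). Since changes to the chain have so far barely moved the number, no step beyond the scatter is expected for compound 4, a 1.2-fold higher number from compound 1 to compound 4 (0.06 log units; within the scatter). Compound 4 is therefore estimated at 8000 nM, within 4000 nM to 16000 nM.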

Compound 4, half-maximal effective concentration: 7100 nM
Beside the measured number, compound 4's estimate is 1.1-fold (0.05 log units) above it; measured number inside the range.
By their numbers in this assay, from the lowest: compounds 1, 4, 3 and 2 (each within the scatter of the next).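

Shortening the hept-6-en-1-yl chain to pent-4-en-1-yl, a change in chain length rather than in the end of the chain, leaves the number in place, with a 1.0-fold higher number from compound 1 to compound 4 (0.01 log units; within the scatter). The shortened chain also stays level with the other two chains, with a 1.1-fold lower number from compound 3 to compound 4 (0.04 log units; within the scatter) and a 1.4-fold lower number from compound 2 to compound 4 (0.14 log units; within the scatter). No measurement at hand explains why this position tolerates such changes. Still open, from the compounds shown here alone, is whether a chain ending in an amine or a carboxylic acid, or a much shorter group such as methyl, would move the number beyond the scatter.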